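Working notes on cytotoxicity across four related compounds

A few compounds are considered here, and "the series" means these few. Any claim that something is new, unique, unknown or untested is made for them only; others in the source may bear on it.

Measured so far:
compound 1 `Cc1ccc(C(=O)N2CCN(CC(=O)N3CCN(CCCc4c[nH]c5ccc(F)cc45)CC3)CC2)cc1` — 141000 nM
compound 2 `O=C(CN1CCN(C(=O)c2ccc(F)cc2)CC1)N1CCN(CCCc2c[nH]c3ccc(F)cc23)CC1` — 102000 nM
compound 3 `COc1ccc2[nH]cc(CCCN3CCN(C(=O)CN4CCN(C(=O)c5ccc(C)cc5)CC4)CC3)c2c1` — 147000 nM

All three numbers come from an ADME assay on HEK293 cells (Homo sapiens) for cytotoxicity, read by MTT assay, with a stated time of 72 h; on this read-out higher numbers stand for weaker inhibition and lower numbers for stronger inhibition. They sit close together; none of the three can be called more or less toxic than another on this read-out.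

Compound 1 and compound 2 differ in one place: fluoro in place of methyl on an aromatic carbon. The step that this change made in this assay is a 1.4-fold lower number from compound 1 to compound 2 (0.14 log units; within the scatter).

Compound 1 and compound 3 differ in the core, and that difference is methoxy in place of fluoro on an aromatic carbon. Its step in this assay is a 1.0-fold higher number from compound 1 to compound 3 (0.02 log units; within the scatter), so the two cores are, on the evidence here, indistinguishable on cytotoxicity.

Compound 4 `COc1ccc2[nH]cc(CCCN3CCN(C(=O)CN4CCN(C(=O)c5ccc(F)cc5)CC4)CC3)c2c1` has not yet been measured. It stands to compound 3 as compound 2 stands to compound 1: fluoro in place of methyl on an aromatic carbon. The place line for this change reads word for word as it does for the change from compound 1 to compound 2, so it is the same change, now made on the core of compound 3.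

Expectation for compound 4 in this assay: the step is estimated as a 1.4-fold lower number from compound 3 to compound 4 (0.15 log units; within the scatter) because the only precedent for this change is a 1.4-fold lower number from compound 1 to compound 2 (0.14 log units; within the scatter), which stayed within the scatter. Starting from compound 3 with 147000 nM, compound 4 is therefore expected to give about 105000 nM, most likely between 55000 nM and 210000 nM. Within the data shown here, the single precedent is the sole basis for this estimate.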

Compound 4, half-maximal inhibitory concentration: > 200000 nM
Compound 4 ended at the assay's limit; the forecaster's own chance of this, stated with the estimate: 20%; at least 1.9-fold (0.27 log units) between middle value and limit.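

In this assay compound 4 reads > 200000 nM, which is a limit of the assay and not a number. Fluoro in place of methyl on an aromatic carbon, made on the core of compound 3, gives an at least 1.3-fold higher number from compound 3 to compound 4 (0.13 log units; that floor lies within the scatter), so this single pair neither shows that the change carries over from the core of compound 1 nor shows that it fails to: the same change on two cores in this assay, a 1.4-fold lower number (0.14 log units; within the scatter) from compound 1 to compound 2 and an at least 1.3-fold higher number (0.13 log units; that floor lies within the scatter) from compound 3 to compound 4; the limit leaves it open whether they differ. The core change read on the fluoro pair, methoxy in place of fluoro on an aromatic carbon, gives an at least 1.9-fold higher number from compound 2 to compound 4 (0.29 log units; that floor lies within the scatter), and whether it depends on the 4-methylphenyl or 4-fluorophenyl group also stays unresolved: the same change on two cores in this assay, a 1.0-fold higher number (0.02 log units; within the scatter) from compound 1 to compound 3 and an at least 1.9-fold higher number (0.29 log units; that floor lies within the scatter) from compound 2 to compound 4; the limit leaves it open whether they differ.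

The compounds shown leave open how the two changes compare on a pair in which both compounds give a number rather than a limit, and whether a group such as an amine or a carboxylic acid in place of the fluoro would separate from the 4-methylphenyl and 4-fluorophenyl compounds. Also open, going by these compounds, is whether a longer chain linking the two halves of these molecules would shift the reading in this assay.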